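The source may report more compounds than this note shows. Statements on the series, on what has been measured and on what is new or still open speak of the compounds shown alone.

Measured in a functional assay on LNCaP cells (Homo sapiens) for antiproliferative activity, read by propidium iodide staining, with a stated time of 96 h; on this read-out lower numbers stand for stronger inhibition and higher numbers for weaker inhibition:
- compound 1 `CC(O)(CSc1ccc(S(F)(F)(F)(F)F)cc1)C(=O)Nc1ccc(S(F)(F)(F)(F)F)cc1`: 18300 nM
- compound 2 `CC(O)(COc1cccc(S(F)(F)(F)(F)F)c1)C(=O)Nc1cc(C(F)(F)F)cc(C(F)(F)F)c1`: 3000 nM
- compound 3 `CC(O)(CS(=O)(=O)c1ccc(F)cc1)C(=O)Nc1ccc(S(F)(F)(F)(F)F)cc1`: 18200 nM

Compound 3 at 18200 nM sits level with compound 1 at 18300 nM, within the scatter. Compound 2 at 3000 nM gives a lower number than compound 3, and that gap lies beyond the scatter.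

The next compound is compound 4 `CC(O)(CS(=O)(=O)c1ccc(OC(F)(F)F)cc1)C(=O)Nc1ccc(S(F)(F)(F)(F)F)cc1`. It carries trifluoromethoxy in place of fluoro on an aromatic carbon, para to a large group: trifluoromethoxy in place of fluoro on an aromatic carbon.

Among the measured compounds shown here, no two measured compounds differ in one place only, so the series gives no direct guide to the size of this step. The expectation starts from compound 3 at 18200 nM and allows a small move toward a lower number in this assay, probably within the scatter. The expected change is a 1.5-fold lower number from compound 3 to compound 4 (0.18 log units; within the scatter). For compound 4 the estimated value is 12000 nM, with an expected range of 4500 nM to 30000 nM.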

Compound 4, half-maximal inhibitory concentration: 92800 nM
For compound 4 the middle estimate is 7.7-fold (0.89 log units) below the measured one, outside the stated range (above it).
By their numbers in this assay, from the lowest: compound 2; then compounds 3 and 1 (each within the scatter of the next); then compound 4.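

In this assay, among the compounds shown here, this is the first comparison between compounds that differ in one place only. It shows that the group on an aromatic carbon, para to a large group, can shift the read-out: trifluoromethoxy in place of fluoro gives a 5.1-fold higher number from compound 3 to compound 4 (0.71 log units; beyond the scatter), so the group with five heavy atoms goes with weaker inhibition than the one with a single heavy atom, in this one pair. Nothing in the data shown bears on the reason for this step.

Open, as far as these compounds go, is how methoxy, chloro, an amine or a carboxylic acid at this same position would compare with fluoro and trifluoromethoxy. From the compounds shown here alone, with a single pair carrying this change, it is also open whether the step keeps its direction and size when the rest of the structure differs.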